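Aryl Swap on the Ring Nitrogen of Compound 2

The compounds below may be only part of what the source reports. "The series", "measured", "known", "first", "only" and "open" are said of these compounds alone.

For the measured compounds named here, compound 2 `CCNC(=O)c1cc(Oc2ccc(NC(=O)c3cc4cccnc4n(-c4ccc(F)cc4)c3=O)cc2)ccn1` gives 190 nM in a functional assay on HT-29 cells (Homo sapiens) for antiproliferative activity, read by MTT assay, with a stated time of 72 h (a higher number here means a weaker inhibitor, a lower number a stronger inhibitor), the lowest of the two numbers so far. Compound 1 `CNC(=O)c1cc(Oc2ccc(NC(=O)c3cc4cccnc4n(-c4ccc(Br)cc4)c3=O)cc2)ccn1` gives 1180 nM in this assay, a gap beyond the scatter, but the two structures differ in more than one place, so only the values themselves are set side by side. Compound 3 `CCNC(=O)c1cc(Oc2ccc(NC(=O)c3cc4cccnc4n(-c4ccc(C(F)(F)F)cc4Cl)c3=O)cc2)ccn1` carries the change (2-chloro-4-(trifluoromethyl)phenyl in place of 4-fluorophenyl on an aromatic nitrogen), 2-chloro-4-(trifluoromethyl)phenyl in place of 4-fluorophenyl on an aromatic nitrogen. Going by the values given here, no single-point step anchors this change. A modest weakening is expected, a 1.7-fold higher number from compound 2 to compound 3 (0.23 log units; within the scatter). Compound 3 is expected at 320 nM, within 80 nM to 1300 nM.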

Compound 3, half-maximal inhibitory concentration: 4770 nM
Estimate against measurement, compound 3: 15-fold (1.17 log units) below, outside the stated range (above it).
By their numbers in this assay, from the lowest: compound 2; then compound 1; then compound 3.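

For the compounds shown here, on the aromatic nitrogen, the aryl group matters in this assay: 2-chloro-4-(trifluoromethyl)phenyl in place of 4-fluorophenyl gives a 25-fold higher number from compound 2 to compound 3 (1.40 log units; beyond the scatter), the only single-place step so far. The entering group adds both chlorine and trifluoromethyl, so this step does not separate their contributions. No measurement here bears on the reason for the loss.

Still open, as far as these compounds go, is how a phenyl carrying chlorine alone or trifluoromethyl alone would compare with these compounds. A methoxy group on the same phenyl also remains an open comparison.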